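This account rests on a few compounds, and the source may have more. Where it says the series, first, only, none or still open, it means among the compounds named here.

Measured so far:
- compound 1 `CN1CCN(c2ccc(-c3cc4c(N5CCN(S(=O)(=O)/C=C/c6ccccc6)CC5)ncnc4s3)cc2)CC1` gives 8670 nM
- compound 2 `CCS(=O)(=O)N1CCN(c2ncnc3sc(-c4ccc(N5CCN(C)CC5)cc4)cc23)CC1` gives 10600 nM
- compound 3 `CN1CCN(c2ccc(-c3cc4c(N5CCN(S(=O)(=O)N6CCCCC6)CC5)ncnc4s3)cc2)CC1` gives 7570 nM

All values come from a functional assay on MDA-MB-436 cells (Homo sapiens) for antiproliferative activity, read by MTT assay, with a stated time of 48 h (a higher number here means a weaker inhibitor, a lower number a stronger inhibitor), and cannot be ranked, since compound 3 sits within the scatter of both neighbours: a 1.1-fold lower number from compound 1 to compound 3 (0.06 log units; within the scatter) and a 1.4-fold lower number from compound 2 to compound 3 (0.15 log units; within the scatter) are its two steps.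

Next comes compound 4 `CN1CCN(c2ccc(-c3cc4c(N5CCN(S(=O)(=O)C6CC6)CC5)ncnc4s3)cc2)CC1`, which carries cyclopropyl in place of piperidin-1-yl on a sulfonyl sulfur in the shared core.

All three measured steps changed the group at this same place. Within the data shown here, the third, a 1.2-fold higher number from compound 1 to compound 2 (0.09 log units; within the scatter) as well, stays small, so 2-phenylethenyl, ethyl and piperidin-1-yl have not separated in this assay so far. Among the measured compounds shown here, no cyclopropyl compound has been measured, so this group itself is untested, and only three compounds support the expectation of no step beyond the scatter.

For compound 4 the estimated value is 9000 nM with an expected range from 5000 nM to 16000 nM (an estimate only). The expected change is a 1.2-fold higher number from compound 3 to compound 4 (0.08 log units; within the scatter) (an estimate only).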

Compound 4, half-maximal inhibitory concentration: 10600 nM
Beside the measured number, compound 4's estimate is 1.2-fold (0.07 log units) below it, within the range that was stated.
By their numbers in this assay, from the lowest: compounds 3, 1, 2 and 4 (each within the scatter of the next).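

In this assay, cyclopropyl on the sulfonyl sulfur stays within the scatter of all three earlier groups: piperidin-1-yl (a 1.4-fold higher number from compound 3 to compound 4 (0.15 log units; within the scatter)), ethyl (no change at the digits printed from compound 2 to compound 4 (within the scatter)) and 2-phenylethenyl (a 1.2-fold higher number from compound 1 to compound 4 (0.09 log units; within the scatter)). The change from piperidin-1-yl to cyclopropyl swaps a six-membered ring with a hetero atom for a three-membered ring of carbon only, and even this does not separate the two compounds. Four groups at this place now remain unseparated, so the series shows no ranking among them, and no available measurement bears on the reason for this.

Going by these compounds, it remains open whether any group on this sulfonyl sulfur can produce a step beyond the scatter, for example a primary amine, a carboxylic acid or a longer alkyl chain. The compounds shown also leave open whether replacing the sulfonyl with a carbonyl would change the number.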